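The compounds below may be only part of what the source reports. "The series", "measured", "known", "first", "only" and "open" are said of these compounds alone.

Measured so far:
- compound 1 `O=C(Nc1ccc(Cl)cc1)C1(c2ccc3c(n2)CCN3c2ccccn2)CCC1`: 53 mL/min/kg
- compound 2 `COC(=O)N1c2ccc(C3(NC(=O)c4ccc(F)cc4)CC3)cc2[C@@H]2CC[C@@H]21`: 29 mL/min/kg

Both values come from an ADME assay on the whole organism (Rattus norvegicus, strain Wistar Han) for pharmacokinetics, at a dose of 0.05 mg/kg by the intravenous route (a higher number here means faster removal of the compound, a lower number slower removal), which follows how quickly the body clears a compound from the blood. Compound 2 gives 29 mL/min/kg and compound 1 gives 53 mL/min/kg. These two numbers lie within the usual scatter of each other, so the data do not separate them, and compound 2 stands level with compound 1.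

The next compound is compound 3 `COC(=O)N1c2ccc(C3(NC(=O)c4ccc(F)cc4)CC3)cc2[C@H]2CC[C@H]21`, and the change from compound 2 is purely one of spatial arrangement: the two compounds have the same atoms and bonds and differ only in configuration as drawn: 2 of 2 stereo elements differ (all stereocentres are inverted: mirror images); a stereocentre at a saturated ring carbon is drawn S in compound 2 and R in compound 3; a stereocentre at a saturated ring carbon is drawn S in compound 2 and R in compound 3. Compound 3 is thus the mirror image of compound 2, with all stereocentres inverted.

Going by the values given here, no measured pair here shows what such an inversion does to clearance, so there is no direct precedent. The starting point is therefore compound 2 at 29 mL/min/kg, with no direction favoured and a wide range kept open. The expected result is no change at the digits printed from compound 2 to compound 3 (within the scatter), a step no larger than the scatter. For compound 3, the estimated clearance in this assay is 29 mL/min/kg, with an expected range of 14 mL/min/kg to 58 mL/min/kg.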

Compound 3, clearance: 32 mL/min/kg
The estimate for compound 3 lay 1.1-fold (0.04 log units) below the measured number; low and high end bracket the measured number.
By their numbers in this assay, from the lowest: compounds 2, 3 and 1 (each within the scatter of the next).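

In this assay, the mirror-image pair gives a 1.1-fold higher number from compound 2 to compound 3 (0.04 log units; within the scatter), so the data do not separate the two forms when both stereocentres are inverted together. The earlier compounds shown here could not show this, since compound 1 and compound 2 differ in many places and no single change could be read from them. This pair gives a clean comparison of the two mirror-image forms because only one kind of difference separates them: the fact that compounds 2 and 3 differ only in the configuration as drawn

From the compounds shown here alone, the result covers only the inversion of both stereocentres at once in this one structure, so it remains open how clearance would respond if just one of them were inverted, a change that would give a compound that is not a mirror image of compound 2. Going by these compounds, it also remains open how clearance would respond to a change of atoms rather than of arrangement, such as a carboxylic acid or an amine in place of the fluorine shared by compound 2 and compound 3.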